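This account rests on a few compounds, and the source may have more. Where it says the series, first, only, none or still open, it means among the compounds named here.

Compound 1 `Cc1ccc2cc(CN(Cc3ccc(F)cc3)Cc3ccc(C(C)C)cc3)c(=O)[nH]c2c1` and compound 2 `Cc1ccc2cc(CN(Cc3ccc(F)cc3)Cc3ccc(C(C)(C)C)cc3)c(=O)[nH]c2c1` share one core and differ only by methyl in place of hydrogen on a saturated chain carbon bound to an aromatic carbon and two saturated chain carbons. In a toxicity assay on MDCK cells (Canis lupus familiaris) for cytotoxicity, read by crystal violet staining, with a stated time of 48 h (on this read-out lower numbers stand for higher toxicity in this test and higher numbers for lower toxicity in this test), compound 1 reaches only the limit > 33000 nM, which is not a number. Compound 2 likewise stops at the limit > 33000 nM. The step that the two limits leave unreadable from compound 1 to compound 2 therefore cannot be sized. Compound 3 `Cc1ccc2[nH]c(=O)c(CN(CCCO)Cc3ccc(C(C)(C)C)cc3)cc2c1` carries a different core; the difference between the two cores is not broken down here. In this assay compound 3 gives the limit > 10000 nM, again not a number. Compound 4 `CCc1ccc2[nH]c(=O)c(CN(CCCO)Cc3ccc(C(C)(C)C)cc3)cc2c1` is not yet measured and differs from compound 3 by methyl in place of hydrogen on a saturated chain carbon bound to an aromatic carbon. Among the compounds with values here, this is the same kind of change as the one between compound 1 and compound 2, though there the place was a saturated chain carbon bound to an aromatic carbon and two saturated chain carbons, whereas here it is a saturated chain carbon bound to an aromatic carbon. Because all three values shown sit at the limit of > 10000 nM in this assay, at which 1 of the 3 values shown sits, or (the limit of > 33000 nM in this assay, at which 2 of the 3 values shown sit), only a small expected step, a step that the limit leaves unreadable from compound 3 to compound 4, is assumed. Compound 4 is expected to give 33000 nM in this assay, most likely again as a limit, within a range from 10000 nM to 100000 nM.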

Compound 4, half-maximal cytotoxic concentration: > 10000 nM
Compound 4 ended at the assay's limit; the forecaster's own chance of this, stated with the estimate: 85%; the middle value does not contradict the limit.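

In this assay compound 3 and compound 4 both stop at a limit and not at a number, so no step can be read between them: the limit of > 10000 nM in this assay, at which 2 of the 4 values shown sit. The compounds shown leave open what the half-maximal cytotoxic concentration of each one actually is, and whether the added methyl changes it at all.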